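A few compounds are considered here, and "the series" means these few. Any claim that something is new, unique, unknown or untested is made for them only; others in the source may bear on it.

Measured so far:
Compound 1 `N#CC1=C(N)Oc2c(c3nc4ccccc4nc3c3ccccc23)C12C(=O)N(Cc1cnnn1-c1ccc([N+](=O)[O-])cc1)c1ccccc12`: in an ADME assay on HUVEC cells (Homo sapiens) for antiproliferative activity, read by MTT assay, with a stated time of 48 h (on this read-out lower numbers stand for stronger inhibition and higher numbers for weaker inhibition), compound 1 gives > 50000 nM, which is a limit of the assay.
Compound 2 `N#CC1=C(N)Oc2c(c3nc4ccccc4nc3c3ccccc23)C12C(=O)N(Cc1cnnn1-c1cc(Cl)ccc1Cl)c1ccccc12`: in this assay compound 2 gives > 50000 nM, which is a limit of the assay.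
Compound 3 `CCc1ccccc1-n1nncc1CN1C(=O)C2(C(C#N)=C(N)Oc3c(N)cc4nc5ccccc5nc4c32)c2ccccc21`: in this assay compound 3 gives > 50000 nM, which is a limit of the assay.

Compound 3 thus stands at the limit of > 50000 nM in this assay, at which 3 of the 3 values shown sit, and the two other values shown are limits of the same kind, so no order among the three can be read. For the measured compounds named here, the one single-point step that has been measured, a step that the two limits leave unreadable from compound 1 to compound 2, is itself hidden between two limits.

Compound 4 `N#CC1=C(N)Oc2c(N)cc3nc4ccccc4nc3c2C12C(=O)N(Cc1cnnn1-c1cc(Cl)ccc1Cl)c1ccccc12` is the next member. It is made from compound 3 by one change: 2,5-dichlorophenyl in place of 2-ethylphenyl on an aromatic nitrogen. The same entering group appears in the measured step from compound 1 to compound 2, but that step is unreadable, and the leaving group there differs from the one here, so the step gives no size to carry over. Nothing in the data therefore points to a readable shift in this assay in either direction, and a change beyond the scatter is not expected.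

The step expected for compound 4 is a step that the limit leaves unreadable from compound 3 to compound 4. Compound 4 is accordingly estimated at 60000 nM, with a range from 15000 nM to 250000 nM, most likely reported again as a limit.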

Compound 4, half-maximal inhibitory concentration: > 50000 nM
Compound 4 ended at the assay's limit (the forecaster's own chance of this, stated with the estimate: 85%); the middle value lies beyond the limit too.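

In this assay, for the compounds shown here, compound 4 gives > 50000 nM, which is a limit of the assay, so the step from compound 3 to compound 4 cannot be read and no new step emerges. All the compounds shown share one position: the limit of > 50000 nM in this assay, at which 4 of the 4 values shown sit. The compounds shown leave open whether compound 1, compound 2, compound 3 and compound 4 differ at all in this assay.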